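The source may hold more compounds than are shown below. What is called first, only, known or untested is meant among the compounds shown, and "the series" means these compounds.

Measured compounds and values in a functional assay on MOLT-4 cells (Homo sapiens) for cytotoxicity, read by CCK-8 assay, with a stated time of 72 h; on this read-out lower numbers stand for stronger inhibition and higher numbers for weaker inhibition:
- compound 1 `COc1ccccc1/C=c1/[nH]c(=O)/c(=C\c2ccccc2OC)n(C)c1=O`: compound 1 gives "not determined" (no result reported)
- compound 2 `C=CCn1c(=O)/c(=C\c2cccc(F)c2)[nH]c(=O)/c1=C\c1ccccc1OC`: compound 2 gives 6500 nM
- compound 3 `C=CCn1c(=O)/c(=C\c2ccccc2OC)[nH]c(=O)/c1=C\c1ccccc1OC`: compound 3 gives 13100 nM

Compound 3 has the highest number of the two that were reported, and its nearest neighbour is compound 2; the step of a 2.0-fold higher number from compound 2 to compound 3 (0.30 log units; within the scatter) lies within the scatter, so the two cannot be ranked against each other. Compound 4 `C=CCn1c(=O)/c(=C\c2cccc(C)c2)[nH]c(=O)/c1=C\c1ccccc1OC` is not yet measured. It differs from compound 3 in one place: 3-methylphenyl in place of 2-methoxyphenyl on a double-bonded chain carbon bound to an aromatic carbon. Within the data shown here, the only measured step that bears on this change is the one between compound 2 and compound 3, where a group on a different ring position in the same place was exchanged, and that step stayed within the scatter. With a small set like this, and with both known points so close together, there is no basis to expect a shift beyond the scatter in either direction in this assay. The estimated step of a 1.6-fold lower number from compound 3 to compound 4 (0.21 log units; within the scatter) is therefore expected to be modest, pointing, if anywhere, toward the number of compound 2. The estimate for compound 4 is 8000 nM, expected to fall between 3000 nM and 20000 nM.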

Compound 4, half-maximal inhibitory concentration: 16000 nM
Compound 4: middle estimate off by 2.0-fold (0.30 log units), on the low side, and the stated range covers the measured number.
By their numbers in this assay, from the lowest: compounds 2, 3 and 4 (each within the scatter of the next, the first and the last beyond it).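

In this assay, 3-methylphenyl in place of 2-methoxyphenyl on a double-bonded chain carbon bound to an aromatic carbon gives a 1.2-fold higher number from compound 3 to compound 4 (0.09 log units; within the scatter), so compound 3 and compound 4 cannot be ranked against each other, even though the group that enters has no oxygen and one heavy atom fewer. The comparison with the 3-fluorophenyl group adds something new: methyl in place of fluoro on an aromatic carbon gives a 2.5-fold higher number from compound 2 to compound 4 (0.39 log units; beyond the scatter), a modest step, but the first in this small set to lie beyond the scatter, and it suggests that the group at this place can shift the number. Nothing measured here explains this difference between fluoro and methyl.

Since compound 3 lies within the scatter of both compound 2 and compound 4, this single modest step is thin support for any trend. On these data alone, it remains open what an unsubstituted phenyl ring, or a phenyl ring carrying an amine or a carboxylic acid, would give at this place, and whether any of them would move the number further than fluoro and methyl do.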